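Three Sulfonamides Without Measurable Cytotoxicity, and a Fourth

The compounds below may be only part of what the source reports. "The series", "measured", "known", "first", "only" and "open" are said of these compounds alone.

Compound 1, `CC1CCN(C2CCN(S(=O)(=O)c3ccc(C#N)cc3)CC2)CC1` — > 5000 nM
Compound 2, `CC1CCN(C2CCN(S(=O)(=O)c3ccc(-c4ccccc4)cc3)CC2)CC1` — > 5000 nM
Compound 3, `CCCOc1ccc(S(=O)(=O)N2CCC(N3CCC(C)CC3)CC2)cc1` — > 5000 nM

In an ADME assay on HCT-116 cells (Homo sapiens) for cytotoxicity, read by CellTiter-Glo, with a stated time of 72 h (on this read-out higher numbers stand for weaker inhibition and lower numbers for stronger inhibition), compound 1 gives > 5000 nM, which is a limit of the assay and not a number. Compound 2 gives > 5000 nM, likewise a limit. Compound 3 gives > 5000 nM, again a limit. Because all three sit at the limit of > 5000 nM in this assay, at which 3 of the 3 values shown sit, none of the steps among them can be read: a step that the two limits leave unreadable from compound 1 to compound 2, a step that the two limits leave unreadable from compound 1 to compound 3 and a step that the two limits leave unreadable from compound 2 to compound 3 are all unreadable in size. Going by the values given here, compound 1 therefore stands where the other two stand, at the limit, with no measured step that ranks it against either.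

Compound 4 is `COc1cccc(S(=O)(=O)N2CCC(N3CCC(C)CC3)CC2)c1`. It differs from compound 1 by 3-methoxyphenyl in place of 4-cyanophenyl on a sulfonyl sulfur. The three measured steps all bear on a change of the group on the sulfonyl sulfur, and all three left the value at the limit, so they give no reading of size in this assay for a change of this kind. On that basis no step beyond the scatter is expected in this assay, and the value of compound 4 is expected to remain a limit. Compound 4 is estimated at 8000 nM, within 3000 nM to 30000 nM. The step that this estimate implies, a step that the limit leaves unreadable from compound 1 to compound 4, is expected to be unreadable, as the earlier ones were.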

Compound 4, half-maximal inhibitory concentration: > 5000 nM
Compound 4: no number, only a limit (the forecaster's own chance of this, stated with the estimate: 85%); the middle value lies beyond the limit too.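

In this assay compound 4 gives > 5000 nM, which is a limit of the assay and not a number. No step from compound 1 to compound 4, or to any other compound shown, can be read, because compound 4 sits where compound 1, compound 2 and compound 3 sit: the limit of > 5000 nM in this assay, at which 4 of the 4 values shown sit. The compounds shown leave open whether any change of the group on the sulfonyl sulfur would give a measurable value.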